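The compounds below may be only part of what the source reports. "The series", "measured", "known", "first", "only" and "open" are said of these compounds alone.

Compound 1 `Clc1ccc(Cn2cc(C3CC(c4ccncc4)=NO3)c3ccccc32)cc1` and compound 2 `COc1ccc2c(c1)c(C1CC(c3ccncc3)=NO1)cn2Cc1ccc(Cl)cc1` share a core and differ by a methoxy in place of hydrogen on an aromatic carbon. In a functional assay on HEK293 cells (Homo sapiens) for inhibition, read by MTT assay, with a stated time of 48 h (a lower number here means a stronger inhibitor, a higher number a weaker inhibitor), compound 1 gives 10200 nM, while compound 2 gives 14200 nM, the higher of the two numbers, though a 1.4-fold higher number from compound 1 to compound 2 (0.14 log units; within the scatter). Compound 3 `COc1ccc2[nH]cc(C3CC(c4ccncc4)=NO3)c2c1` differs from compound 2 by hydrogen in place of 4-chlorobenzyl on an aromatic nitrogen. Among the measured compounds shown here, no measured step involves this change, so the step from compound 2 to compound 3 cannot be anchored to earlier pairs; a modest weakening is expected, a 2.1-fold higher number from compound 2 to compound 3 (0.32 log units; beyond the scatter). Compound 3 is therefore estimated at 30000 nM, between 8000 nM and 100000 nM.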

Compound 3, half-maximal inhibitory concentration: > 100000 nM
Compound 3: a limit, no number; the forecaster's own chance of this, stated with the estimate: 25%; at least 3.3-fold (0.52 log units) between middle value and limit.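

Replacing 4-chlorobenzyl with hydrogen on the aromatic nitrogen gives an at least 7.0-fold higher number from compound 2 to compound 3 (0.84 log units; beyond the scatter) in this assay. This is the first change among these compounds to move the number beyond the scatter, so what sits on this nitrogen matters in a way the methoxy change did not show. The value of compound 3 is a limit and not a number: the limit of > 100000 nM in this assay, at which 1 of the 3 values shown sits. Still open, going by these compounds, is whether a small methyl on this nitrogen would keep the number of compound 2, or whether a longer chain such as phenethyl would serve as well. On these data alone, whether the chlorine itself is needed, as a plain benzyl would show, also stays open.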